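The compounds below may be only part of what the source reports. "The series", "measured", "known", "first", "only" and "open" are said of these compounds alone.

Measured in an in vitro assay on 293-EBNA cells for binding affinity to corticotropin-releasing factor receptor 1 (Homo sapiens); a higher number here means a weaker inhibitor, a lower number a stronger inhibitor:
compound 1, `CCN(CC)c1nc(C)nc2c1ncn2-c1ccc(C(C)C)cc1Br`, 12.4 nM
compound 2, `CCCCN(CC)c1nc(C)nc2c1ncn2-c1ccc(C(C)C)cc1Br`, 4.3 nM

Compound 2 gives the lowest of the two numbers in this assay; its nearest neighbour is compound 1, which lies a 2.9-fold lower number from compound 1 to compound 2 (0.46 log units; beyond the scatter) away. The unmeasured compound 3 is `CCCCN(CCCC)c1nc(C)nc2c1ncn2-c1ccc(C(C)C)cc1Br`. It differs from compound 2 by ethyl in place of hydrogen on a saturated chain carbon, two bonds along the chain from a nitrogen on an aromatic ring; seen one bond further out, the amino substituent goes from butyl(ethyl)amino to dibutylamino. Among the measured compounds shown here, the only measured step that bears on it is the one from compound 1 to compound 2, which is the same change on the other chain and gave a 2.9-fold lower number from compound 1 to compound 2 (0.46 log units; beyond the scatter). Because a 2.9-fold lower number from compound 1 to compound 2 (0.46 log units; beyond the scatter) was modest, the same change applied again is expected to give a step of similar or smaller size in this assay, again toward a lower number. The estimate for compound 3 is therefore 2.5 nM, within 1 nM to 8 nM, which would mean an expected step of a 1.7-fold lower number from compound 2 to compound 3 (0.24 log units; within the scatter).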

Compound 3, inhibition constant: 6.1 nM
The estimate for compound 3 lay 2.4-fold (0.39 log units) below the measured number, within the range that was stated.
By their numbers in this assay, from the lowest: compounds 2 and 3 (each within the scatter of the next); then compound 1.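

In this assay, ethyl in place of hydrogen on a saturated chain carbon gave a 2.9-fold lower number from compound 1 to compound 2 (0.46 log units; beyond the scatter) on one chain, but the same change on the other chain gave a 1.4-fold higher number from compound 2 to compound 3 (0.15 log units; within the scatter), so the first step did not repeat and butyl(ethyl)amino and dibutylamino cannot be told apart here. Dibutylamino in place of diethylamino on an aromatic carbon still gave a 2.0-fold lower number from compound 1 to compound 3 (0.31 log units; beyond the scatter) as the whole change across both chains. Nothing in hand accounts for the difference between the two ethyl steps.

Open, as far as these compounds go, is whether this level persists with a longer chain such as hexyl, a branched chain such as isobutyl, or a chain ending in an ether or an amine. Also open, from the compounds shown here alone, is whether the two ethyl steps would read the same with a group other than isopropyl or bromine on the aryl ring of the shared core.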